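Aryl Swap on the Fused Core Against Gastric Cancer Cells

The compounds below may be only part of what the source reports. "The series", "measured", "known", "first", "only" and "open" are said of these compounds alone.

Compound 1 `COc1cc(Nc2cc(Nc3ccc(Oc4ccncc4-c4cccnc4)c(F)c3)ncn2)cc(OC)c1` gives 1750 nM. Compound 2 `Cn1c(=O)c(C(=O)Nc2ccc(Oc3ccncc3-c3cccnc3)c(F)c2)nn(-c2c(Cl)cccc2Cl)c1=O` gives 3930 nM. Compound 3 `COc1ccc(-n2nc(C(=O)Nc3ccc(Oc4ccncc4-c4cccnc4)c(F)c3)c3ccccc3c2=O)cc1` gives 740 nM.

These numbers come from a functional assay on MKN-45 cells (Homo sapiens) for cytotoxicity, read by MTT assay, with a stated time of 72 h; a lower number here means a stronger inhibitor, a higher number a weaker inhibitor. Among the three, compound 3 stands lowest; compound 1 is nearest, with a gap beyond the scatter, and compound 2 furthest, also beyond the scatter. Compound 4 `O=C(Nc1ccc(Oc2ccncc2-c2cccnc2)c(F)c1)c1nn(-c2cccc(F)c2)c(=O)c2ccccc12` has not yet been measured. It differs from compound 3 by 3-fluorophenyl in place of 4-methoxyphenyl on an aromatic nitrogen. Among the compounds with values here, no step between two measured compounds covers this kind of change, so nothing in the data sets its size. In this assay the expected step is a 1.2-fold higher number from compound 3 to compound 4 (0.09 log units; within the scatter), no larger than the scatter. Compound 4 is therefore estimated at 900 nM, with a range from 350 nM to 2500 nM.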

Compound 4, half-maximal inhibitory concentration: 27 nM
Beside the measured number, compound 4's estimate is 33-fold (1.52 log units) above it, and the stated range ends above it.
By their numbers in this assay, from the lowest: compound 4; then compound 3; then compound 1; then compound 2.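

In this assay the aryl group on the aromatic nitrogen turns out to be a highly sensitive position: 3-fluorophenyl in place of 4-methoxyphenyl gives a 27-fold lower number from compound 3 to compound 4 (1.44 log units; beyond the scatter) from one change alone. The earlier compounds shown here, with no single-place step among them, could not show this. No measurement here accounts for a step of this size.

The compounds shown leave open whether the fluorine, its place on the ring or the loss of the methoxy group carries the step. From the compounds shown here alone, how a plain phenyl, a 4-fluorophenyl or an amine on that ring would read also remains open.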